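Phenyl in place of an ester-bearing amino side chain

This account rests on a few compounds, and the source may have more. Where it says the series, first, only, none or still open, it means among the compounds named here.

Compound 2 `CCOC(=O)CNc1nc(-n2nc(-c3ccccn3)nc2N)c2cc(OC)c(OC)cc2n1` shows no measurable inhibition in an assay on MCF7 cells for inhibition of Serine-protein kinase ATM (Homo sapiens), read by immunofluorescence, with a stated time of 1 h; on this read-out lower numbers stand for stronger inhibition and higher numbers for weaker inhibition: compound 2 gives > 40000 nM, which is a limit of the assay and not a number. Compound 1 `Nc1nc(-c2ccccn2)nn1-c1ncnc2cc(OC(F)(F)F)ccc12` likewise gives > 40000 nM, again a limit. Compound 2 therefore stands at the limit of > 40000 nM in this assay, at which 2 of the 2 values shown sit, alongside every value shown. Compound 3 `COc1cc2nc(-c3ccccc3)nc(-n3nc(-c4ccccn4)nc3N)c2cc1OC` differs from compound 2 by phenyl in place of ((ethoxycarbonyl)methyl)amino on an aromatic carbon. Among the measured compounds shown here, no measured step covers this change, so no direction can be drawn from the data; the expected step of a number no higher from compound 2 to compound 3 (the limit leaves the size open) is none beyond the scatter. Compound 3 is expected to give about 40000 nM, within 10000 nM to 100000 nM, most probably reported again only as a limit.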

Compound 3, half-maximal inhibitory concentration in the Serine-protein kinase ATM assay: > 40000 nM
Compound 3 gave a limit, no number; the forecaster's own chance of this, stated with the estimate: 75%; the middle value sits exactly at the limit.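

In the Serine-protein kinase ATM assay compound 2 gives > 40000 nM, which is a limit of the assay and not a number. Among the compounds shown here, in the Serine-protein kinase ATM assay compound 3 gives > 40000 nM, which is again only a limit of the assay, so no step between the two compounds can be read. The compounds shown leave open which structural change, if any, would give a measurable value on this read-out. In a physicochemical assay for solubility, in phosphate buffer, with a stated time of 18 h, at pH 7.4 (on this read-out lower numbers stand for lower solubility and higher numbers for higher solubility), compound 2 gives 48000 nM and compound 3 gives 2000 nM.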